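A few compounds are considered here, and "the series" means these few. Any claim that something is new, unique, unknown or untested is made for them only; others in the source may bear on it.

Compound 1 `CN(C(=O)c1ccc(Br)cc1)c1ccc2[nH]c(-c3n[nH]c4ccccc34)cc2n1` is the starting point. In a functional assay on HL-60 cells (Homo sapiens) for antiproliferative activity, read by MTT assay, with a stated time of 72 h (a higher number here means a weaker inhibitor, a lower number a stronger inhibitor), compound 1 gives 1080 nM. Compound 2 `COc1ccc(C(=O)N(C)c2ccc3[nH]c(-c4n[nH]c5ccccc45)cc3n2)cc1` carries one change, (methoxy in place of bromo on an aromatic carbon), and in this assay compound 2 gives 3320 nM, so the step is a 3.1-fold higher number from compound 1 to compound 2 (0.49 log units; beyond the scatter). Compound 3 `CN(c1ccc2[nH]c(-c3n[nH]c4ccccc34)cc2n1)S(=O)(=O)c1ccc(Br)cc1` has a different core: the two cores differ by (4-bromophenyl)sulfonyl in place of (4-bromophenyl)carbonyl on a nitrogen on an aromatic ring, and in this assay compound 3 gives 6240 nM, a step of a 5.8-fold higher number from compound 1 to compound 3 (0.76 log units; beyond the scatter). Compound 4 `COc1ccc(S(=O)(=O)N(C)c2ccc3[nH]c(-c4n[nH]c5ccccc45)cc3n2)cc1` has not been measured. It differs from compound 3 by methoxy in place of bromo on an aromatic carbon, made at the same place as the change from compound 1 to compound 2, so it is the same change set on the core of compound 3. That change has been measured only once, and there it weakened inhibition modestly. On these data alone, whether the same holds on the core of compound 3 is untested, so the expectation rests on that single step. Because the change is the one that gave a 3.1-fold higher number from compound 1 to compound 2 (0.49 log units; beyond the scatter), a step of about a 2.7-fold higher number from compound 3 to compound 4 (0.44 log units; beyond the scatter) is expected here. For compound 4 the estimate is 17000 nM, likely between 7000 nM and 45000 nM.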

Compound 4, half-maximal inhibitory concentration: 4340 nM
The estimate for compound 4 lay 3.9-fold (0.59 log units) above the measured number; the whole stated range lies above it.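

In this assay, going from 4-bromophenyl to 4-methoxyphenyl on the core of compound 3 gives a 1.4-fold lower number from compound 3 to compound 4 (0.16 log units; within the scatter), so this pair cannot be told apart. Going by these compounds alone, the same change therefore does not carry over at the same size from the core of compound 1 to the core of compound 3, and the difference between the two steps is larger than repeat measurements alone would explain: the same change on two cores in this assay, a 3.1-fold higher number (0.49 log units; beyond the scatter) from compound 1 to compound 2 and a 1.4-fold lower number (0.16 log units; within the scatter) from compound 3 to compound 4, 4.4-fold (0.65 log units) apart, beyond the scatter of two such steps This rests on only one pair for each core, so it shows that a step measured on one of these cores cannot simply be copied to the other, but it does not show why the two differ or how the change would behave on any further core.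

The compounds shown hold only bromo and methoxy at this place on the ring, each on both cores. On these data alone, how an amine or a carboxylic acid at the same place would behave on the core of compound 1 and on the core of compound 3 stays open.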